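The source may report more compounds than this note shows. Statements on the series, on what has been measured and on what is new or still open speak of the compounds shown alone.

Compound 3 `COc1cccc(CNCCCNc2ccnc3cc(-c4ccccc4)ccc23)c1O` is the point of departure. In an ADME assay on HepG2 cells (Homo sapiens) for cytotoxicity, read by luminescence, CellTiter-Glo and ATP content, with a stated time of 72 h (a lower number here means that less compound is needed, a higher number that more compound is needed for the effect), compound 3 gives 3210 nM, and its number sits between those of its two companions, all three within the scatter of one another. Compound 2 `COc1cccc(CNCCCNc2ccnc3cc(CC(C)C)ccc23)c1O` gives 2920 nM in this assay, and compound 1 `COc1cccc(CNCCCNc2ccnc3cc(Cc4ccc(F)cc4)ccc23)c1O` gives 4780 nM. The steps among them are small: a 1.1-fold higher number from compound 2 to compound 3 (0.04 log units; within the scatter), a 1.5-fold lower number from compound 1 to compound 3 (0.17 log units; within the scatter), and a 1.6-fold lower number from compound 1 to compound 2 (0.21 log units; within the scatter).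

Compound 4 `COc1cccc(CNCCCNc2ccnc3cc(-c4cccc5ccccc45)ccc23)c1O` is not yet measured. It differs from compound 3 at the same position that is varied among the three measured compounds: naphthalen-1-yl in place of phenyl on an aromatic carbon.

Going by the values given here, the steps that bear on this change are the two that end at compound 3, where the data show a 1.1-fold higher number from compound 2 to compound 3 (0.04 log units; within the scatter) and a 1.5-fold lower number from compound 1 to compound 3 (0.17 log units; within the scatter), and each exchange of the group at this aromatic carbon has left the number within the scatter. A step of a 1.1-fold higher number from compound 3 to compound 4 (0.02 log units; within the scatter) is therefore expected, nothing beyond the scatter. For compound 4 the estimate in this assay is 3400 nM, with a range from 1500 nM to 8000 nM.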

Compound 4, half-maximal effective concentration: 2520 nM
Compound 4: the middle estimate sits 1.3-fold (0.13 log units) above what was measured; the range from low to high includes it.
By their numbers in this assay, from the lowest: compounds 4, 2, 3 and 1 (each within the scatter of the next).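

Putting two fused aromatic rings at this carbon, naphthalen-1-yl in place of the single ring of phenyl, adds four carbon atoms and still leaves this assay with only a 1.3-fold lower number from compound 3 to compound 4 (0.11 log units; within the scatter) and no step beyond the scatter. The same holds when naphthalen-1-yl is set against the other two groups, with a 1.2-fold lower number from compound 2 to compound 4 (0.06 log units; within the scatter) and with a 1.9-fold lower number from compound 1 to compound 4 (0.28 log units; within the scatter) as the widest step among the four compounds, so that isobutyl, 4-fluorobenzyl, phenyl and naphthalen-1-yl cannot be told apart at this position. Nothing measured alongside these numbers accounts for this flat picture.

On these data alone, whether an amine, a carboxylic acid or a hydroxyl group at this aromatic carbon would carry the number beyond the scatter remains open. So does whether a longer chain elsewhere on the shared core would do so.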